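This account rests on a few compounds, and the source may have more. Where it says the series, first, only, none or still open, it means among the compounds named here.

Measured in a physicochemical assay for metabolic stability, read by HPLC and mass spectrometry, in phosphate buffer, at 37 degrees C, at pH 7.4; a higher number here means that the compound lasts longer, a lower number that the compound disappears faster:
- Compound 1 `CC(C)(O/N=C(\C(=O)N[C@@H]1C(=O)N(S(=O)(=O)O)[C@@H]1CN1C[C@@H](CN)OC1=O)c1csc(N)n1)C(=O)O`: > 37 h
- Compound 2 `N=C(N)NCc1cn(C[C@@H]2[C@H](NC(=O)/C(=N\OC3(C(=O)O)CC3)c3csc(N)n3)C(=O)N2S(=O)(=O)O)nn1`: 89 h

Going by the values given here, compound 2, at 89 h, holds the only exact number in this assay. For compound 1, > 37 h is a limit of the assay and not a number. Compound 3 `NC[C@@H]1CN(C[C@@H]2[C@H](NC(=O)/C(=N\OC3(C(=O)O)CC3)c3csc(N)n3)C(=O)N2S(=O)(=O)O)C(=O)O1` differs from compound 2 in one place: a group of 8 heavy atoms (4 carbon, 2 nitrogen, 2 oxygen; one five-membered non-aromatic ring with 2 hetero atoms) in place of a group of 10 heavy atoms (4 carbon, 6 nitrogen; one five-membered aromatic ring with 3 hetero atoms), on a saturated chain carbon bound to a saturated ring carbon. A group with one five-membered non-aromatic ring replaces a group with one five-membered aromatic ring, on a saturated chain carbon bound to a saturated ring carbon. Among the compounds with values here, no measured step shows what this swap does, so the expected change, a 1.5-fold lower number from compound 2 to compound 3 (0.17 log units; within the scatter), is none beyond the usual scatter. For compound 3 the estimated half-life is 60 h, with an expected range of 25 h to 130 h.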

Compound 3, half-life: 157 h
The estimate for compound 3 lay 2.6-fold (0.42 log units) below the measured number; measured number outside the range, above it.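

In this assay, a group with one five-membered non-aromatic ring replaces a group with one five-membered aromatic ring, on a saturated chain carbon bound to a saturated ring carbon, giving a 1.8-fold higher number from compound 2 to compound 3 (0.25 log units; within the scatter). This first readable step at this position stays within the usual scatter, so half-life tolerates the swap. The other step, 1-carboxycyclopropyl in place of 1-carboxy-1-methylethyl on an oxygen, cannot be read because compound 1 carries a limit and not a number: the limit of > 37 h in this assay, at which 1 of the 3 values shown sits.

From the compounds shown here alone, whether a six-membered non-aromatic ring or an open chain ending in a hydroxyl at the same place would also stay within the scatter remains open.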